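A few compounds are considered here, and "the series" means these few. Any claim that something is new, unique, unknown or untested is made for them only; others in the source may bear on it.

Measured so far in a functional assay on CNE-2 cells (Homo sapiens) for cytotoxicity, read by MTT assay, with a stated time of 72 h; a lower number here means a stronger inhibitor, a higher number a weaker inhibitor:
compound 1 `O=C(NC(=S)NNc1ncnc2ccccc12)c1ccccc1` gives 1490 nM
compound 2 `COc1cc2ncnc(NNC(=S)NC(=O)c3cccc(Cl)c3)c2cc1OC` gives 7460 nM
compound 3 `COc1cc2ncnc(NNC(=S)NC(=O)c3ccccc3)c2cc1OC` gives 8180 nM

Compound 1 carries the lowest of the three numbers, and its separation from compound 2 and from compound 3 lies beyond the scatter in each case, so compound 1 is the strongest inhibitor among the measured compounds. Compounds 2 and 3 share a core substituted differently from the core of compound 1, and they differ from each other in one place only, on the phenyl ring: a 1.1-fold higher number from compound 2 to compound 3 (0.04 log units; within the scatter). Within the data shown here, that is the only measured step that touches the phenyl ring, and it stays within the scatter.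

Compound 4 `Cc1ccc(C(=O)NC(=S)NNc2ncnc3ccccc23)cc1` has not yet been measured. It differs from compound 1 in one place: methyl in place of hydrogen on an aromatic carbon. Among the measured compounds shown here, the one comparable step, from compound 2 to compound 3, exchanged a substituent on the same ring without moving the number beyond the scatter; no measured step tests a methyl group anywhere. On that basis the expected step is a 1.0-fold higher number from compound 1 to compound 4 (0.00 log units; within the scatter), within the scatter. For the measured compounds named here, compound 4 is therefore expected to give about 1500 nM in this assay, with a range from 650 nM to 3500 nM, the range kept wide as no measured step tests a methyl group.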

Compound 4, half-maximal inhibitory concentration: 17200 nM
Compound 4: middle estimate off by 11-fold (1.06 log units), on the low side; measured number above the stated range.
By their numbers in this assay, from the lowest: compound 1; then compounds 2 and 3 (each within the scatter of the next); then compound 4.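

In this assay, the phenyl ring of compound 1 does not tolerate every change: a 12-fold higher number from compound 1 to compound 4 (1.06 log units; beyond the scatter), with methyl in place of hydrogen para to a large group, so a single added heavy atom at this position is enough to weaken the compound beyond the scatter. The earlier step on a phenyl ring, a 1.1-fold higher number from compound 2 to compound 3 (0.04 log units; within the scatter), stays within the scatter, but it exchanges chloro on the core shared by compounds 2 and 3 and therefore gives no reading of this position on the core of compound 1. Nothing at hand accounts for the size of the methyl step.

From the compounds shown here alone, whether this loss belongs to methyl alone or to any group at this position remains open, and a fluoro, methoxy or ethyl group there would help separate those two readings. Also open, going by these compounds, is whether methyl at the same position on the core shared by compounds 2 and 3 would give a step of similar size, or whether the step is specific to the core of compound 1.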